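Cyclohexyl for isopropyl on the ring nitrogen

The compounds below may be only part of what the source reports. "The series", "measured", "known", "first", "only" and "open" are said of these compounds alone.

Measured so far:
compound 1 `CC(C)N1C(=O)C=C(Cl)C1(O)c1ccccc1`: 200 nM
compound 2 `CC(C)N1C(=O)C=C(Cl)C1(O)c1ccc(Cl)cc1`: 300 nM

Going by the values given here, in an assay on cell membranes for displacement of a labelled ligand from Cholecystokinin receptor type A (Rattus norvegicus), read by CCK-8 assay, with a stated time of 2 h (on this read-out lower numbers stand for stronger inhibition and higher numbers for weaker inhibition), compound 1 gives 200 nM and stands lowest of the two numbers; the only measured step, a 1.5-fold higher number from compound 1 to compound 2 (0.18 log units; within the scatter), concerns a chloro on an aromatic carbon and lies within the scatter. Compound 3 `O=C1C=C(Cl)C(O)(c2ccccc2)N1C1CCCCC1` differs from compound 1 by cyclohexyl in place of isopropyl on an amide-type nitrogen in a ring. Among the compounds with values here, no measured step touches the group on the ring nitrogen, so nothing here bears directly on this change, and the shared core is otherwise unchanged. For compound 3 the expectation in this assay is therefore no step beyond the scatter, no change at the digits printed from compound 1 to compound 3 (within the scatter). Compound 3 is estimated at 200 nM, within 60 nM to 700 nM.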

Compound 3, half-maximal inhibitory concentration: > 10000 nM
Compound 3: only a limit was reported (the forecaster's own chance of this, stated with the estimate: 5%); middle value at least 50-fold (1.69 log units) away from the limit.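

In this assay, the ring nitrogen proves far more sensitive than the aromatic carbon changed earlier, with cyclohexyl in place of isopropyl giving an at least 50-fold higher number from compound 1 to compound 3 (1.69 log units; beyond the scatter). Isopropyl is thus the only group on this nitrogen shown with a measured number. Compound 3 has a limit rather than a number: the limit of > 10000 nM in this assay, at which 1 of the 3 values shown sits.

From the compounds shown here alone, whether methyl, cyclopropyl or an open n-butyl chain on this nitrogen would keep the number of compound 1 remains open. This single change cannot separate the effect of the ring in cyclohexyl from that of its extra carbons.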